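Esters of the acid of compound 1 in a rat assay

This account rests on a few compounds, and the source may have more. Where it says the series, first, only, none or still open, it means among the compounds named here.

Compound 1 `CCCc1nc(C(C)(C)O)c(C(=O)O)n1Cc1ccc(-c2ccccc2C(=O)O)cc1`: 12%
Compound 2 `CCCc1nc(C(C)(C)O)c(C(=O)OCc2coc(=O)o2)n1Cc1ccc(-c2ccccc2C(=O)O)cc1`: 70%
Compound 3 `CCCc1nc(C(C)(C)O)c(C(=O)OCOC(=O)OC(C)C)n1Cc1ccc(-c2ccccc2C(=O)O)cc1`: 71%

The read-out for all three is a functional assay on the whole organism for inhibition, with Rattus norvegicus as the target, with a stated time of 6 h, at a dose of 1 mg/kg; a higher number here means more inhibition at the dose given (going by the name of the read-out), a lower number less inhibition. Compound 1, which carries a free carboxylic acid on the shared core, gives 12%. Compound 2 gives 70% and compound 3 gives 71%. Compound 3 has the top number of the three, but compound 2 lies within the scatter of it, so the two cannot be ranked against each other; only compound 1 stands apart.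

Compound 4 `CCCc1nc(C(C)(C)O)c(C(=O)OC2OC(=O)c3ccccc32)n1Cc1ccc(-c2ccccc2C(=O)O)cc1` is made from compound 3 by the change (a group of 10 heavy atoms (8 carbon, 2 oxygen; one five-membered non-aromatic ring with 1 hetero atom, one six-membered aromatic ring of carbon only) in place of a group of 8 heavy atoms (5 carbon, 3 oxygen; no ring), on an oxygen next to a carbonyl group). Within the data shown here, three measured steps bear on it. Capping the acid of compound 1 with an ester group produced a large rise in both cases: a number 58 percentage points higher from compound 1 to compound 2 (beyond the scatter) and a number 59 percentage points higher from compound 1 to compound 3 (beyond the scatter). Swapping one ester cap for another gave only a number 1 percentage points higher from compound 2 to compound 3 (within the scatter), a change within the scatter. Compound 4 is again an ester cap on the same oxygen, so the expectation is that it keeps the level of compound 2 and compound 3 rather than falling back toward compound 1, and the expected step is a number 6 percentage points lower from compound 3 to compound 4 (within the scatter), within the scatter. Compound 4 is therefore estimated at 65%, with a range from 40% to 85%.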

Compound 4, a percentage reported as inhibition, in the whole organism at one dose (the size of the read-out at that dose, not a potency): 74%
Compound 4: middle estimate off by 9 percentage points, on the low side, and the stated range covers the measured number.
By their numbers in this assay, from the lowest: compound 1; then compounds 2, 3 and 4 (each within the scatter of the next).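

The ester cap on this oxygen can also carry a five-membered non-aromatic ring and a six-membered aromatic ring of carbon only, and in this assay it sits level with the earlier caps: replacing ((isopropoxycarbonyl)oxy)methyl gives a number 3 percentage points higher from compound 3 to compound 4 (within the scatter) and replacing the cap of compound 2 gives a number 4 percentage points higher from compound 2 to compound 4 (within the scatter). Measured against the free acid, the same cap gives a number 62 percentage points higher from compound 1 to compound 4 (beyond the scatter), so all three esters shown stand well clear of the acid, and none goes against this. The three caps differ in size, in their rings and in their count of hydrogen-bond acceptors, yet at this single dose and time the read-out does not separate them.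

No measurement shown accounts for the gap between the esters and the acid or for the likeness among the esters. Also open, going by these compounds, is whether a plain methyl or ethyl ester, or a cap bearing an amine, would reach the level of these three caps, and whether the three caps would still look alike at a lower dose.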